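Para substituent change on the anilino ring: chloro to ethyl

The source may report more compounds than this note shows. Statements on the series, on what has been measured and on what is new or still open speak of the compounds shown alone.

Three members of the series carry the same shared core and differ only in the aryl group on the anilino nitrogen. Compound 1 `C=CC(=O)Nc1cccc(NC(=O)CSc2nc(Nc3ccccc3Cl)c3ccccc3n2)c1` gives 14400 nM in a functional assay on PC-3 cells (Homo sapiens) for inhibition, read by MTT assay, with a stated time of 72 h; on this read-out lower numbers stand for stronger inhibition and higher numbers for weaker inhibition. Compound 2 `C=CC(=O)Nc1cccc(NC(=O)CSc2nc(Nc3cccc(F)c3)c3ccccc3n2)c1` gives 5370 nM in this assay, and compound 3 `C=CC(=O)Nc1cccc(NC(=O)CSc2nc(Nc3ccc(Cl)cc3)c3ccccc3n2)c1` gives 10800 nM. Compound 3 holds the second highest number of the three; its nearest neighbour is compound 1, with a 1.3-fold lower number from compound 1 to compound 3 (0.12 log units; within the scatter), and its furthest is compound 2, with a 2.0-fold higher number from compound 2 to compound 3 (0.30 log units; within the scatter), both within the scatter. Within the data shown here, the only step that clears the scatter is a 2.7-fold lower number from compound 1 to compound 2 (0.43 log units; beyond the scatter), a modest one.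

Compound 4 `C=CC(=O)Nc1cccc(NC(=O)CSc2nc(Nc3ccc(CC)cc3)c3ccccc3n2)c1` differs from compound 3 by ethyl in place of chloro on an aromatic carbon. Among the measured compounds shown here, none of the measured steps swaps a chloro for an alkyl group; they move or exchange halogens on the aryl ring, and all of them are modest or within the scatter. On that basis no step beyond the scatter is expected in this assay, and the estimated change is a 1.1-fold lower number from compound 3 to compound 4 (0.03 log units; within the scatter). Compound 4 is therefore expected to give about 10000 nM in this assay, within a range from 4000 nM to 28000 nM.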

Compound 4, half-maximal inhibitory concentration: 24300 nM
Estimate against measurement, compound 4: 2.4-fold (0.39 log units) below; the range from low to high includes it.
By their numbers in this assay, from the lowest: compounds 2, 3, 1 and 4 (each within the scatter of the next, the first and the last beyond it).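

In this assay, ethyl in place of chloro at this position, para to a large group, gives a 2.3-fold higher number from compound 3 to compound 4 (0.35 log units; beyond the scatter) and so clears the scatter: among the compounds shown, the aryl group here is not limited to halogen exchanges, and this swap of a halogen for an alkyl group moves the number upward. Compared with the 3-fluorophenyl group, the 4-ethylphenyl group gives a 4.5-fold higher number from compound 2 to compound 4 (0.66 log units; beyond the scatter) as the widest gap in the set, whereas against the 2-chlorophenyl group it gives a 1.7-fold higher number from compound 1 to compound 4 (0.23 log units; within the scatter) and stays within the scatter, so compound 4 cannot be called the weakest of the four. No measurement at hand accounts for the step from chloro to ethyl.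

Going by these compounds, all of this rests on a single alkyl group at one position, so it remains open whether the upward move follows chain length or is specific to ethyl. A longer chain such as propyl, or a methoxy group or an amine at the same place, would show whether the rise in the number belongs to alkyl groups alone or extends to other groups that replace chloro.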